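A few compounds are considered here, and "the series" means these few. Any claim that something is new, unique, unknown or untested is made for them only; others in the source may bear on it.

Measured in an ADME assay on BHK-21 cells (Mesocricetus auratus) for cytotoxicity, read by MTT assay, with a stated time of 72 h; a lower number here means that less compound is tolerated, a higher number that more compound is tolerated:
- compound 1 `FC(F)(F)c1ccc(-c2nn(-c3ccccc3)cc2CNc2ccc(Cl)cc2)cc1`: 31000 nM
- compound 2 `Cc1ccc(NCc2cn(-c3ccccc3)nc2-c2ccc(Cl)cc2)cc1`: > 100000 nM (a limit of the assay)
- compound 3 `FC(F)(F)c1ccc(NCc2cn(-c3ccccc3)nc2-c2ccc(Cl)cc2)cc1`: 17000 nM

Not yet measured: compound 4 `Clc1ccc(NCc2cn(-c3ccccc3)nc2-c2ccc(Cl)cc2)cc1`.

Compound 3 at 17000 nM lies within the scatter of compound 1 at 31000 nM. Compound 4 has chloro in place of trifluoromethyl on an aromatic carbon. Within the data shown here, the only measured step bearing on this is an at least 5.8-fold lower number from compound 2 to compound 3 (0.76 log units; beyond the scatter), with trifluoromethyl in place of methyl. That step starts from a limit and involves a different group, so a step of that size is not expected here. In this assay, the expected step, a 1.5-fold higher number from compound 3 to compound 4 (0.17 log units; within the scatter), is toward a slightly higher number and stays within the scatter. For compound 4 the estimated value is 25000 nM, with an expected range of 9000 nM to 70000 nM.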

Compound 4, half-maximal cytotoxic concentration: 73000 nM
Compound 4: the middle estimate sits 2.9-fold (0.47 log units) below what was measured, outside the stated range (above it).
By their numbers in this assay, from the lowest: compounds 3 and 1 (each within the scatter of the next); then compound 4. At a limit, above all of these: compound 2.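

In this assay, chloro in place of trifluoromethyl on an aromatic carbon gives a 4.3-fold higher number from compound 3 to compound 4 (0.63 log units; beyond the scatter). The same change, made where compound 1 carries its trifluoromethyl, gives a 2.4-fold higher number from compound 1 to compound 4 (0.37 log units; beyond the scatter), so the number rises with chloro in both places shown. Compound 2 gives > 100000 nM, a limit of the assay. Chloro in place of methyl on an aromatic carbon gives an at least 1.3-fold lower number from compound 2 to compound 4 (0.13 log units; that floor lies within the scatter). This step starts from a limit: the limit of > 100000 nM in this assay, at which 1 of the 4 values shown sits.

Still open, from the compounds shown here alone, is how an amine or a carboxylic acid in this place would read in this assay. The compounds shown also leave open whether the rise with chloro extends beyond this pair of groups.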